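A few compounds are considered here, and "the series" means these few. Any claim that something is new, unique, unknown or untested is made for them only; others in the source may bear on it.

Measured in a functional assay on K562 cells (Homo sapiens) for antiproliferative activity, read by MTT assay, with a stated time of 48 h; a lower number here means a stronger inhibitor, a higher number a weaker inhibitor:
- Compound 1 `Oc1ccc2cc1Oc1ccc(cc1)CCc1ccc(CN3CCCC3)c(O)c1-c1ccc(cc1O)CC2`: 4820 nM
- Compound 2 `Oc1ccc2cc1Oc1ccc(cc1)CCc1ccc(CN3CCCCC3)c(O)c1-c1ccc(cc1O)CC2`: 5880 nM
- Compound 3 `COc1ccc(N2CCN(Cc3ccc4c(c3O)-c3ccc(cc3O)CCc3ccc(O)c(c3)Oc3ccc(cc3)CC4)CC2)cc1`: > 20000 nM

Compound 3 has no number, only a limit: the limit of > 20000 nM in this assay, at which 1 of the 3 values shown sits. Compound 4 `CN1CCN(Cc2ccc3c(c2O)-c2ccc(cc2O)CCc2ccc(O)c(c2)Oc2ccc(cc2)CC3)CC1` differs from it in one place, with methyl in place of 4-methoxyphenyl on an amine nitrogen in a ring.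

Within the data shown here, the only measured step, a 1.2-fold higher number from compound 1 to compound 2 (0.09 log units; within the scatter), swaps pyrrolidin-1-yl for piperidin-1-yl and stays within the scatter. It bears on this change only loosely, but it suggests that compounds 1 and 2 can stand as one reference level. With the large aromatic group gone, compound 4 is expected to lie near compound 2 at 5880 nM, so a clear move to a lower number is expected. The expected change is an at least 3.0-fold lower number from compound 3 to compound 4 (0.48 log units; beyond the scatter). For compound 4 the estimated value is 6500 nM, with an expected range of 2500 nM to 16000 nM.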

Compound 4, half-maximal inhibitory concentration: 3310 nM
Estimate against measurement, compound 4: 2.0-fold (0.29 log units) above, and the stated range covers the measured number.
By their numbers in this assay, from the lowest: compounds 4, 1 and 2 (each within the scatter of the next). At a limit, above all of these: compound 3.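

In this assay, among these compounds, the nitrogen of the piperazine ring proves sensitive to its substituent, which the earlier compounds could not show: methyl in place of 4-methoxyphenyl gives an at least 6.0-fold lower number from compound 3 to compound 4 (0.78 log units; beyond the scatter). That size is a minimum, as compound 3 has only a limit: the limit of > 20000 nM in this assay, at which 1 of the 4 values shown sits. With methyl on that nitrogen, the piperazine ring matches the simpler rings, with a 1.8-fold lower number from compound 2 to compound 4 (0.25 log units; within the scatter) and a 1.5-fold lower number from compound 1 to compound 4 (0.16 log units; within the scatter).

Still open, going by these compounds, is whether ethyl, benzyl or unsubstituted phenyl on that nitrogen would track compound 4 or compound 3. That would help separate the contribution of the aromatic ring from that of its methoxy group.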